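The source may hold more compounds than are shown below. What is called first, only, known or untested is meant among the compounds shown, and "the series" means these compounds.

Values measured in a functional assay on A549 cells (Homo sapiens) for antiproliferative activity, with a stated time of 5 days (a higher number here means a weaker inhibitor, a lower number a stronger inhibitor), for the compounds so far:

compound 1 `COc1ccc(-n2nc(-c3ccc4ccccc4c3)nc2N2C(=O)COC23C=CC(=O)C=C3)cc1` gives 260 nM
compound 2 `Cc1ccc(-n2nc(-c3ccc4ccccc4c3)nc2N2C(=O)COC23C=CC(=O)C=C3)cc1` gives 110 nM
compound 3 `O=C1C=CC2(C=C1)OCC(=O)N2c1nc(-c2ccc3ccccc3c2)nn1-c1ccc2ccccc2c1` gives 250 nM

Compound 3 stands level with the 4-methoxyphenyl analogue (a 1.0-fold lower number from compound 1 to compound 3 (0.02 log units; within the scatter)) and clearly above the 4-methylphenyl analogue (a 2.3-fold higher number from compound 2 to compound 3 (0.36 log units; beyond the scatter)), which has the lowest number of the set. Compound 4 `O=C1C=CC2(C=C1)OCC(=O)N2c1nc(-c2ccc3ccccc3c2)nn1-c1ccc(Cl)cc1` carries 4-chlorophenyl in place of naphthalen-2-yl on an aromatic nitrogen. The two steps just given bear on this change, since both exchange a single substituted phenyl for naphthalen-2-yl at this same nitrogen. One made no difference and the other was modest. The methoxy-to-methyl step (a 2.4-fold lower number from compound 1 to compound 2 (0.37 log units; beyond the scatter)) shows that the substituent on the phenyl ring can shift the number by a similar amount. Among the compounds with values here, no chlorine-bearing compound has been measured, so the expectation is for a small move toward a lower number, possibly none beyond the scatter. The expected step is a 1.6-fold lower number from compound 3 to compound 4 (0.19 log units; within the scatter) in this assay. For compound 4 the estimated value is 160 nM, with an expected range of 70 nM to 350 nM.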

Compound 4, half-maximal inhibitory concentration: 400 nM
Compound 4: the middle estimate sits 2.5-fold (0.40 log units) below what was measured; measured number outside the range, above it.
By their numbers in this assay, from the lowest: compound 2; then compounds 3, 1 and 4 (each within the scatter of the next).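

In this assay, 4-chlorophenyl on this aromatic nitrogen stays within the scatter of naphthalen-2-yl (a 1.6-fold higher number from compound 3 to compound 4 (0.20 log units; within the scatter)) and of 4-methoxyphenyl (a 1.5-fold higher number from compound 1 to compound 4 (0.19 log units; within the scatter)), so these three groups cannot be told apart here. Compound 2 alone stands apart: the chloro-for-methyl exchange (a 3.6-fold higher number from compound 2 to compound 4 (0.56 log units; beyond the scatter)) is the largest step in the set, and the steps from compound 2 to each of the other three lie beyond the scatter, which makes it the strongest of the four. Nothing available explains why methyl separates from chloro and methoxy here.

On these data alone, it remains open how a phenyl ring bearing an amine, a carboxylic acid or a longer chain would behave on this nitrogen. As far as these compounds go, all four compounds also keep naphthalen-2-yl on the other ring atom, so whether these steps hold with a different group there is unknown.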